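This account rests on a few compounds, and the source may have more. Where it says the series, first, only, none or still open, it means among the compounds named here.

Measured compounds:
- compound 1 `CCC(=O)Nc1cc(C(=O)Nc2ccc(Br)cc2)ccc1OC`: 90.4 uM
- compound 2 `CCC(=O)Nc1cc(C(=O)Nc2cccc(Cl)c2)ccc1OC`: 602 uM
- compound 3 `CCC(=O)Nc1cc(C(=O)Nc2cccc(SC)c2)ccc1OC`: 324 uM

In an ADME assay on MDCK cells (Canis lupus familiaris) for cytotoxicity, read by cytopathic effect, with a stated time of 48 h (a higher number here means that more compound is tolerated, a lower number that less compound is tolerated), compound 3 gives 324 uM, the second highest of the three numbers. Its nearest neighbour is compound 2, which shows 602 uM, and the two stand within the scatter of each other, as a 1.9-fold lower number from compound 2 to compound 3 (0.27 log units; within the scatter) shows. Compound 1 gives 90.4 uM, and the gap between compound 1 and compound 3 lies beyond the scatter: a 3.6-fold higher number from compound 1 to compound 3 (0.55 log units; beyond the scatter).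

Compound 4 `CCC(=O)Nc1cc(C(=O)Nc2nccs2)ccc1OC` has not yet been measured in this assay. It differs from compound 3 in one place: 1,3-thiazol-2-yl in place of 3-(methylsulfanyl)phenyl on an amide-type nitrogen. All three measured steps concern the group on this same amide-type nitrogen, so all three bear on the change. The steps of a 6.7-fold higher number from compound 1 to compound 2 (0.82 log units; beyond the scatter) and a 3.6-fold higher number from compound 1 to compound 3 (0.55 log units; beyond the scatter) were modest, and the step of a 1.9-fold lower number from compound 2 to compound 3 (0.27 log units; within the scatter) stayed within the scatter. Within the data shown here, exchanging one group for another at this position has therefore moved this assay by at most a modest amount, and none of the measured steps involved a five-membered ring with two hetero atoms, so the direction for compound 4 is uncertain.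

For compound 4 the step of a 1.1-fold higher number from compound 3 to compound 4 (0.03 log units; within the scatter) is expected to stay within the scatter, and compound 4 is estimated at 350 uM, with a likely range from 120 uM to 900 uM.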

Compound 4, half-maximal toxic concentration: > 655 uM
Compound 4: a limit, no number; the forecaster's own chance of this, stated with the estimate: 25%; middle value at least 1.8-fold (0.27 log units) from the limit.
By their numbers in this assay, from the lowest: compound 1; then compounds 3 and 2 (each within the scatter of the next). At a limit, above all of these: compound 4.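

In this assay compound 4 gives > 655 uM, which is a limit of the assay and not a number, and it is the only compound shown that stands at such a limit: the limit of > 655 uM in this assay, at which 1 of the 4 values shown sits. Two of the new steps have floors that lie within the scatter, an at least 2.0-fold higher number from compound 3 to compound 4 (0.30 log units; that floor lies within the scatter) and an at least 1.0-fold higher number from compound 2 to compound 4 (0.03 log units; that floor lies within the scatter), so the size of these gaps stays unfixed, whereas an at least 7.2-fold higher number from compound 1 to compound 4 (0.86 log units; beyond the scatter) clears the scatter even at its floor. The earlier compounds shown here carried only substituted phenyl rings on this amide-type nitrogen, and this result shows that a five-membered aromatic ring with 2 hetero atoms can take their place there with no drop in the number in any of the three pairs.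

From the compounds shown here alone, the true value of compound 4 stays open, and so does whether the ring sulfur, the ring nitrogen or the smaller ring as a whole accounts for the result. Also open, going by these compounds, is how a pyridin-2-yl ring or a plain alkyl chain on this same nitrogen would compare with 1,3-thiazol-2-yl.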